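A few compounds are considered here, and "the series" means these few. Any claim that something is new, unique, unknown or untested is made for them only; others in the source may bear on it.

Measured so far:
- Compound 1, `CC(OC(=O)C(C)C)OC(=O)N1CCN(C(=O)c2nc(Nc3cc(C4CC4)[nH]n3)c3cc(Cl)ccc3n2)C[C@H]1C`, gives 71.7% in an assay for inhibition of serine/threonine-protein kinase PAK 4 (Homo sapiens), read by FRET and Z'-LYTE, with a stated time of 60 min, tested at 50 uM, in the presence of a further agent that is not named here; a lower number here means a weaker effect, a higher number a stronger effect of the compound at the concentration tested.
- Compound 2, `COC(=O)N1CCN(C(=O)c2nc(Nc3cc(C4CC4)[nH]n3)c3cc(Cl)ccc3n2)C[C@H]1C`, gives 98.5% in this assay.

Compound 2 stands highest of these two numbers; its nearest neighbour is compound 1, reached through a number 26.8 percentage points higher from compound 1 to compound 2 (beyond the scatter), a modest step beyond the scatter. Compound 3, `CC(OC(=O)N1CCN(C(=O)c2nc(Nc3cc(C4CC4)[nH]n3)c3cc(Cl)ccc3n2)C[C@H]1C)OC(=O)C(C)(C)C`, has not yet been measured. It differs from compound 2 by 1-(((tert-butyl)carbonyl)oxy)ethyl in place of methyl on an oxygen next to a carbonyl group. For the measured compounds named here, the only measured step that bears on this change is the one from compound 1 to compound 2, where a group of the same kind, differing only in the tert-butyl against isopropyl part, was replaced by methyl and the read-out rose by the amount just given. Going the other way, from methyl back to a larger ester-bearing group, a drop of roughly the same size is therefore expected in this assay, as a number 28.5 percentage points lower from compound 2 to compound 3 (beyond the scatter). Compound 3 is thus estimated at 70%, within 50% to 90%.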

Compound 3, a percentage reported as inhibition, at one concentration (the size of the read-out at that concentration, not a potency) in the serine/threonine-protein kinase PAK 4 assay: 65.3%
For compound 3 the middle estimate is 4.7 percentage points above the measured one; the range from low to high includes it.
By their numbers in the serine/threonine-protein kinase PAK 4 assay, from the lowest: compounds 3 and 1 (each within the scatter of the next); then compound 2.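

In the serine/threonine-protein kinase PAK 4 assay, 1-(((tert-butyl)carbonyl)oxy)ethyl in place of methyl gives a number 33.2 percentage points lower from compound 2 to compound 3 (beyond the scatter) and the step between the two ester-bearing groups is a number 6.4 percentage points lower from compound 1 to compound 3 (within the scatter) so among these compounds the read-out separates methyl from both larger groups, while the tert-butyl and isopropyl ends cannot be told apart. In a physicochemical assay, read by HPLC, in phosphate buffer, with a stated time of 2 h, at pH 7.4 (on this read-out higher numbers stand for a more stable compound and lower numbers for a less stable compound), compound 2 gives 100% and compound 3 gives 90.5% which is a number 9.5 percentage points lower from compound 2 to compound 3 (within the scatter) so this change leaves the percent remaining within the usual scatter. Nothing available explains why the larger group lowers the inhibition read-out.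

Still open, as far as these compounds go, is where the read-out falls with a group of intermediate length on this oxygen, such as ethyl. A plain butyl chain without an ester would show whether added length alone gives the same drop.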